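Sulfomethyl in place of sulfoamino: compound 3 awaits its number

This account rests on a few compounds, and the source may have more. Where it says the series, first, only, none or still open, it means among the compounds named here.

Compound 1 `O=C(CS(=O)(=O)O)Nc1nc2ccc([N+](=O)[O-])cc2s1` gives 590 ug/mL in a physicochemical assay for solubility, read by HPLC, at pH 6; on this read-out higher numbers stand for higher solubility and lower numbers for lower solubility
Compound 2 `Cc1c(Br)cc(NC(=O)NS(=O)(=O)O)cc1Br` gives 9.5 ug/mL in this assay

Of these two numbers, compound 2 holds the lower one, and compound 1 stands higher by a gap well beyond the scatter. Their cores differ, so that gap cannot be pinned on any single group. In going to compound 3 `Cc1c(Br)cc(NC(=O)CS(=O)(=O)O)cc1Br` the core of compound 2 stays, and sulfomethyl takes the place of sulfoamino on a carbonyl carbon sulfomethyl in place of sulfoamino on a carbonyl carbon with nothing else altered.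

Going by the values given here, no measured pair isolates this change. Among the compounds with values here, the one hint is that compound 1, which also has sulfomethyl on a carbonyl carbon, gives 590 ug/mL on its own core. On that slim ground a rise is expected, though one far smaller than the gap between the two measured compounds, as the data do not show how much of that gap goes with the core. In this assay the expected step of a 4.2-fold higher number from compound 2 to compound 3 (0.62 log units; beyond the scatter) is upward and estimated to be modest, with the low end of its range inside the scatter. For compound 3 the estimated solubility is 40 ug/mL with an expected range from 8 ug/mL to 200 ug/mL in repeat measurements.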

Compound 3, solubility: 740 ug/mL
Compound 3: the middle estimate sits 19-fold (1.27 log units) below what was measured; measured number above the stated range.
By their numbers in this assay, from the lowest: compound 2; then compounds 1 and 3 (each within the scatter of the next).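

In this assay, going by these compounds alone, exchanging sulfoamino for sulfomethyl on a carbonyl carbon gives a 78-fold higher number from compound 2 to compound 3 (1.89 log units; beyond the scatter), the first step in this set in which a single change can be read, and it is a large one. The earlier gap lay between compounds with different cores, whereas this step shows that on the core of compound 2 the change at this one place is enough on its own to move the number far beyond the scatter, even though it only puts a carbon where a nitrogen stood and lowers the count of hydrogen-bond donors. No measurement at hand accounts for the size of this step.

This is one matched pair on one core, so the compounds shown leave open whether the same exchange would carry a step of similar size on the core of compound 1. They also leave open how this position would read with a carboxylic acid in place of the sulfo group, or with a longer chain such as sulfoethyl on the carbonyl carbon.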